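The source may report more compounds than this note shows. Statements on the series, on what has been measured and on what is new or still open speak of the compounds shown alone.

Measured so far:
Compound 1 (`C=C1[C@@H](OC(C)=O)C[C@@H]2[C@](C)(CO[Si](C)(C)C(C)(C)C)[C@H](OC(C)=O)CC[C@@]2(C)[C@@H]1C[C@@H](Nc1ccc(OC)c(OC)c1)C1=CCOC1=O`) 4310 nM
Compound 2 (`C=C1[C@@H](OC(C)=O)C[C@@H]2[C@](C)(COC=O)[C@H](OC(C)=O)CC[C@@]2(C)[C@@H]1C[C@@H](Nc1ccccc1)C1=CCOC1=O`) 26200 nM
Compound 3 (`C=C1[C@@H](OC(C)=O)C[C@@H]2[C@](C)(CO[Si](C)(C)C(C)(C)C)[C@H](OC(C)=O)CC[C@@]2(C)[C@@H]1C[C@@H](Nc1ccccc1)C1=CCOC1=O`) 4840 nM

In a functional assay on MCF7 cells (Homo sapiens) for cytotoxicity, read by sulforhodamine B assay (on this read-out higher numbers stand for weaker inhibition and lower numbers for stronger inhibition), compound 3 reads 4840 nM and so lies within the scatter of compound 1 and well under compound 2. Compound 4 (`C=C1[C@@H](OC(C)=O)C[C@@H]2[C@](C)(CO[Si](C)(C)C(C)(C)C)[C@H](OC(C)=O)CC[C@@]2(C)[C@@H]1C[C@@H](Nc1cccc(OC)c1)C1=CCOC1=O`) carries methoxy in place of hydrogen on an aromatic carbon, turning phenyl to 3-methoxyphenyl. The closest evidence is the swap on the amine nitrogen (a 1.1-fold higher number from compound 1 to compound 3 (0.05 log units; within the scatter)), where phenyl stands in place of 3,4-dimethoxyphenyl. The larger step (a 5.4-fold lower number from compound 2 to compound 3 (0.73 log units; beyond the scatter)) concerns a different group, on an oxygen on a saturated carbon, and says little here. In this assay no step beyond the scatter is therefore expected in either direction. The expected change is small (a 1.1-fold lower number from compound 3 to compound 4 (0.03 log units; within the scatter)). Compound 4 is estimated at 4500 nM (expected range 2400 nM to 8500 nM).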

Compound 4, half-maximal inhibitory concentration: 28100 nM
Estimate against measurement, compound 4: 6.2-fold (0.80 log units) below; the whole stated range lies below it.
By their numbers in this assay, from the lowest: compounds 1 and 3 (each within the scatter of the next); then compounds 2 and 4 (each within the scatter of the next).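

In this assay the change from phenyl to 3-methoxyphenyl gives a 5.8-fold higher number from compound 3 to compound 4 (0.76 log units; beyond the scatter), so the flat step on the amine nitrogen did not mean that methoxy groups on this ring leave the number unchanged. Removing one methoxy from compound 1 gives a 6.5-fold higher number from compound 1 to compound 4 (0.81 log units; beyond the scatter), so the effect of a methoxy here depends on what else the ring carries. Nothing shown here explains this dependence. From the compounds shown here alone, whether a hydroxyl, a chlorine or an ethoxy group at the same place would act like methoxy stays open. So does whether the step persists with the group of compound 2 on the oxygen.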